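The source may hold more compounds than are shown below. What is called first, only, known or untested is meant among the compounds shown, and "the series" means these compounds.

Compound 1, `COc1ccc(-c2nc(SCC(=O)c3sc(-c4ccccc4)nc3C)nc(N)c2C#N)cc1`: 17.2%
Compound 2, `COc1ccc(-c2nc(C)c(C(=O)CSc3nc(N)c(C#N)c(-c4ccc(Cl)cc4)n3)s2)cc1`: 3.9%
Compound 3, `Cc1nc(-c2ccc(Cl)cc2)sc1C(=O)CSc1nc(-c2ccccc2)c(C#N)c(=O)[nH]1`: 11.4%

In a functional assay on U-87MG ATCC cells for antiproliferative activity against U-87 MG (Homo sapiens), read by MTT assay, with a stated time of 48 h, tested at 100 uM (on this read-out lower numbers stand for a stronger effect and higher numbers for a weaker effect at the one concentration tested), compound 2 gives the lowest of the three numbers. Its nearest neighbour is compound 3, whose number is higher by an amount within the usual scatter, so no order between these two can be claimed. Compound 1 stands furthest away, its number higher by a gap beyond the scatter.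

Compound 4, `COc1ccc(-c2nc(C)c(C(=O)CSc3nc(N)c(C#N)c(-c4ccccc4)n3)s2)cc1`, has not yet been measured in this assay. It differs from compound 2 in one place: hydrogen in place of chloro on an aromatic carbon. Going by the values given here, no measured pair shows this same change on the shared core, so its size cannot be read off from the data at hand; compounds 1 and 3 differ from compound 2 in other places as well and are not clean comparisons. The expected step is a number 5.1 percentage points higher from compound 2 to compound 4 (within the scatter), a small move toward a higher number that stays within the scatter. The estimate for compound 4 in this assay is 9%, within 2% to 25%.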

Compound 4, a percentage reported as activity, at one concentration (the size of the read-out at that concentration, not a potency): 5.25%
Compound 4: middle estimate off by 3.8 percentage points, on the high side; low and high end bracket the measured number.
By their numbers in this assay, from the lowest: compounds 2, 4, 3 and 1 (each within the scatter of the next, the first and the last beyond it).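

Going by these compounds alone, the pair gives the first clean reading of this position on the shared core: in this assay, going from 4-chlorophenyl to phenyl, with hydrogen in place of chloro para to a large group, gives a number 1.4 percentage points higher from compound 2 to compound 4 (within the scatter). At the one concentration tested, the read-out therefore does not separate the two compounds, and the chloro is not required for the effect seen with compound 2. No measurement at hand gives a reason for this result.

What an amine or a carboxylic acid on this same aromatic carbon would give remains open, since the compounds shown compare only chloro and hydrogen there. A single concentration also leaves open whether compound 2 and compound 4 would separate at lower concentrations.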